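The source may hold more compounds than are shown below. What is called first, only, known or untested is meant among the compounds shown, and "the series" means these compounds.

Compound 2 `CCCCCc1ccc(C#Cc2c(-c3ccc(CCCCC)cc3)oc3nc(=O)n(Cc4cn(Cc5ccccc5)nn4)cc23)cc1` is tested in a functional assay on CFPAC-1 cells (Homo sapiens) for antiproliferative activity, read by MTT assay, with a stated time of 72 h; a lower number here means a stronger inhibitor, a higher number a weaker inhibitor. In this assay compound 2 reaches only the limit of > 100000 nM, which is not a number. Going by the values given here, compound 1 `O=c1nc2oc(CCCCl)c(C#CCCCCl)c2cn1Cc1cn(-c2ccc(Cl)cc2)nn1`, which also carries 1-(4-chlorophenyl)-1H-1,2,3-triazol-4-yl, sits at the limit of > 100000 nM in this assay, and this is the only evidence on hand: the limit of > 100000 nM in this assay, at which 2 of the 2 values shown sit. Compound 3 `CCCCCc1ccc(C#Cc2c(-c3ccc(CCCCC)cc3)oc3nc(=O)n(Cc4cn(-c5ccc(Cl)cc5)nn4)cc23)cc1` differs from compound 2 by 4-chlorophenyl in place of benzyl on an aromatic nitrogen. With both known values at the limit, no step can be read. The step of a number no higher from compound 2 to compound 3 (the limit leaves the size open) is expected to be none beyond the scatter. Compound 3 is therefore estimated at 100000 nM, in the range 30000 nM to 300000 nM.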

Compound 3, half-maximal inhibitory concentration: > 100000 nM
Compound 3 gave a limit, no number; the forecaster's own chance of this, stated with the estimate: 85%; the middle value sits exactly at the limit.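

In this assay, going by these compounds alone, both compound 2 and compound 3 give limits, not numbers, so no step between them can be read. On these data alone, whether benzyl and 4-chlorophenyl differ at all in this assay stays open, as does whether any compound on this core gives a measurable value.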